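Swapping the naphthyl ether of compound 1 for a dichlorophenyl ether

The source may hold more compounds than are shown below. What is called first, only, known or untested is meant among the compounds shown, and "the series" means these compounds.

Compound 1 `Cn1cc(/C=C/C(=O)NS(=O)(=O)c2cc(F)c(F)cc2F)c2c(Oc3ccc4ccccc4c3)cccc21` is one of two compounds tested in an assay on isolated protein for displacement of a labelled ligand from prostaglandin E2 receptor EP3 subtype (Homo sapiens), tested at 20 uM, in the presence of a further agent that is not named here (a lower number here means a stronger inhibitor, a higher number a weaker inhibitor), where compound 1 gives 28 nM and compound 2 `Cn1cc(/C=C/C(=O)NS(=O)(=O)c2cccc(Cl)c2)c2c(Oc3ccc4ccccc4c3)cccc21` gives 35 nM; the two numbers sit within the usual scatter of each other, so neither can be called the stronger. For the measured compounds named here, the only measured step, a 1.3-fold higher number from compound 1 to compound 2 (0.10 log units; within the scatter), concerns the aryl group on the sulfonyl sulfur and not the ether side of the shared core. Compound 3 `Cn1cc(/C=C/C(=O)NS(=O)(=O)c2cc(F)c(F)cc2F)c2c(Oc3ccc(Cl)cc3Cl)cccc21` differs from compound 1 at that ether: 2,4-dichlorophenyl in place of naphthalen-2-yl on an oxygen on an aromatic ring. Going by the values given here, no measured step touches this part of the molecule, so there is no direct guide to the size or direction of the change. Compound 3 is therefore expected to land near compound 1, with a wide margin to allow for an unseen effect, giving an estimated 1.6-fold higher number from compound 1 to compound 3 (0.21 log units; within the scatter). The estimate for compound 3 in this assay is 45 nM, with a range from 12 nM to 180 nM.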

Compound 3, half-maximal inhibitory concentration: 16.7 nM
The estimate for compound 3 lay 2.7-fold (0.43 log units) above the measured number; the measured number falls inside the stated range.
By their numbers in this assay, from the lowest: compounds 3, 1 and 2 (each within the scatter of the next, the first and the last beyond it).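

For the compounds shown here, at the oxygen on an aromatic ring, the earlier compounds carried only naphthalen-2-yl, so nothing showed whether that larger group of two fused rings was needed. In this assay, 2,4-dichlorophenyl in place of naphthalen-2-yl gives a 1.7-fold lower number from compound 1 to compound 3 (0.22 log units; within the scatter), so among these compounds a single aromatic ring bearing two chlorines serves as well as the two-ring group. No information is available here to explain why the two groups give such similar results.

The compounds shown leave open how a plain phenyl, a 4-chlorophenyl or a saturated cyclohexyl on that oxygen would compare, and so whether either chlorine matters. On these data alone, it also remains open whether 2,4-dichlorophenyl would give a similar result alongside the 3-chlorophenyl on the sulfonyl sulfur of compound 2.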